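Fluoro for methoxy in a cytotoxicity series

The compounds below may be only part of what the source reports. "The series", "measured", "known", "first", "only" and "open" are said of these compounds alone.

Compound 1 `COc1ccc(-c2nc3ccccc3s2)cc1NC(=O)c1cc([N+](=O)[O-])ccc1Cl`: > 25000 nM
Compound 2 `COc1ccc(-c2nc3ccccc3s2)cc1NC(=O)c1cc([N+](=O)[O-])c(N2CCN(C)CC2)cc1Cl`: > 25000 nM

In an ADME assay on Raji cells (Homo sapiens) for cytotoxicity, with a stated time of 72 h (a higher number here means that more compound is needed for the effect, a lower number that less compound is needed), compound 1 gives > 25000 nM, which is a limit of the assay and not a number. Compound 2 gives > 25000 nM, likewise only a limit. The step that the two limits leave unreadable from compound 1 to compound 2 therefore cannot be read. Both measured values sit at the same limit (the limit of > 25000 nM in this assay, at which 2 of the 2 values shown sit). Compound 3 `O=C(Nc1cc(-c2nc3ccccc3s2)ccc1F)c1cc([N+](=O)[O-])ccc1Cl` differs from compound 1 by fluoro in place of methoxy on an aromatic carbon. For the measured compounds named here, no measured step bears on this change. Compound 3 is expected to stay at the limit as well, with an estimated 30000 nM (range 10000 nM to 100000 nM). The step that the limit leaves unreadable from compound 1 to compound 3 is the expected outcome, carrying no direction that the data could support.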

Compound 3, half-maximal effective concentration: > 25000 nM
Compound 3: a limit, no number; the forecaster's own chance of this, stated with the estimate: 80%; the middle value is on the limit's open side.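

Compound 3 gives > 25000 nM, a limit and not a number; the step from compound 1 to compound 3 cannot be read. Left open is what concentration any of these compounds needs for the effect in this assay, and whether fluoro in place of methoxy changes it.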